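Demethylation of a Diaryl Pyrazole Urea: Expected Cell Growth Effect

A few compounds are considered here, and "the series" means these few. Any claim that something is new, unique, unknown or untested is made for them only; others in the source may bear on it.

Compound 1 `COc1cc(-c2nn(-c3cccc(NC(=O)Nc4cc(C(F)(F)F)cc(C(F)(F)F)c4)c3)cc2-c2ccncc2)ccc1Cl` was examined in a functional assay on SN12C cells (Homo sapiens) for inhibition, read by sulforhodamine B assay, with a stated time of 48 h (a lower number here means a stronger inhibitor of growth, a higher number a weaker inhibitor of growth), where compound 1 gives 3320 nM. Compound 2 `COc1cc(-c2nn(-c3cccc(NC(=O)Nc4ccc(Cl)c(Cl)c4)c3)cc2-c2ccncc2)ccc1Cl` shares a methoxy group with compound 1, but the difference between the two cores is not broken down here. In this assay compound 2 reaches only a limit, > 50000 nM. Compound 3 `O=C(Nc1cccc(-n2cc(-c3ccncc3)c(-c3ccc(Cl)c(O)c3)n2)c1)Nc1ccc(Cl)c(Cl)c1` arises from compound 2 by hydrogen in place of methyl on an oxygen on an aromatic ring; in this assay compound 3 again reaches only a limit, > 32500 nM. Because both values are limits, the step that the two limits leave unreadable from compound 2 to compound 3 cannot be read from the pair, as the limit of > 50000 nM in this assay, at which 1 of the 3 values shown sits, and the limit of > 32500 nM in this assay, at which 1 of the 3 values shown sits, both show.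

Compound 4 `O=C(Nc1cccc(-n2cc(-c3ccncc3)c(-c3ccc(Cl)c(O)c3)n2)c1)Nc1cc(C(F)(F)F)cc(C(F)(F)F)c1` has not yet been measured. It arises from compound 1 by hydrogen in place of methyl on an oxygen on an aromatic ring, the same kind of change seen from compound 2 to compound 3, made at a place described in the same words. Since that earlier step gave no readable size, the expectation for compound 4 rests on compound 1 alone, at 3320 nM, with a small loss allowed for: the step of a 1.5-fold higher number from compound 1 to compound 4 (0.18 log units; within the scatter) is expected. Compound 4 is thus estimated at 5000 nM, between 1500 nM and 20000 nM.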

Compound 4, concentration for total growth inhibition: 5450 nM
The estimate for compound 4 lay 1.1-fold (0.04 log units) below the measured number; low and high end bracket the measured number.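

In this assay, the change from methoxy to hydroxy on the core of compound 1 gives a 1.6-fold higher number from compound 1 to compound 4 (0.22 log units; within the scatter), so on this core the change leaves compound 1 and compound 4 within the usual scatter of each other. On the other core, compound 2 gives only a limit and no number: the limit of > 50000 nM in this assay, at which 1 of the 4 values shown sits. Compound 3 also gives only a limit, so the step on that core cannot be read, and the pair of compound 1 and compound 4 shows the result on one core without showing that it carries over to another: the limit of > 32500 nM in this assay, at which 1 of the 4 values shown sits.

The compounds shown leave open how a larger ether, such as an ethoxy group, or an amine in place of the hydroxy would read on the 4-chloro-3-hydroxyphenyl group. They also leave open whether the same change would read alike on a urea partner carrying something other than the trifluoromethyl groups of compound 1, such as a carboxylic acid.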